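The source may hold more compounds than are shown below. What is called first, only, known or untested is meant among the compounds shown, and "the series" means these compounds.

Measured compounds in a functional assay on membranes from Sf9 cells for agonist activity at histamine H2 receptor (Homo sapiens), read by scintillation counting and GTPgammaS binding, with a stated time of 90 min; on this read-out higher numbers stand for larger maximal responses and lower numbers for smaller maximal responses:

compound 1, `Cc1nc(N)sc1CCCN/C(N)=N/C(=O)NCC(C)CCc1ccccc1`: 0.69
compound 2, `N/C(=N\C(=O)NCc1ccccc1)NC1CCc2nc(N)sc2C1`: 0.53
compound 3, `CCCCCCNC(=O)/N=C(\N)NCCCc1sc(N)nc1C`: 0.6

Compound 1 gives the highest of the three numbers in this assay. Compound 3 sits closest, within the usual scatter of repeated measurements, so nothing can be said about an order between compound 1 and compound 3. The gap between compound 1 and compound 2 is the largest and lies beyond the scatter; the value of compound 2 is 0.53.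

For the measured compounds named here, no pair of measured compounds differs in one place only, so no step has been measured that would directly guide the move to compound 4, `Cc1ccc(CC(C)CNC(=O)/N=C(\N)NCCCc2sc(N)nc2C)cc1`, which is to be measured in this assay. Compound 4 differs from compound 1 as follows:

4-methylphenyl in place of benzyl on a saturated chain carbon, three bonds along the chain from an amide-type nitrogen

The two compounds hold the same atoms, joined differently, and the groups leaving and entering carry the same counts of heavy atoms, donors and acceptors. The three measured values span a narrow range, and nothing among them points to a large move. For compound 4 no step beyond the scatter is expected; the estimated step is a number 0.040 lower from compound 1 to compound 4 (within the scatter). Compound 4 is therefore expected to give about 0.65 in this assay, with a range from 0.5 to 0.8.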

Compound 4, intrinsic activity: the largest response reached, as a fraction of the reference agonist's: 0.68
For compound 4 the middle estimate is 0.030 below the measured one; measured number inside the range.
By their numbers in this assay, from the lowest: compounds 2, 3, 4 and 1 (each within the scatter of the next, the first and the last beyond it).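

In this assay, 4-methylphenyl in place of benzyl on a saturated chain carbon, three bonds along the chain from an amide-type nitrogen, gives a number 0.010 lower from compound 1 to compound 4 (within the scatter). For the compounds shown here, this is the first pair that differs in one place only, and it shows that this rearrangement of the same atoms, which also reads as phenethyl to 4-methylbenzyl, does not separate the two compounds on maximal response at this position. Nothing available accounts for this outcome.

The compounds shown leave open whether a step beyond the scatter would appear with a group of another kind at this place, such as a pyridine ring, a 4-methoxyphenyl group, an amine or a longer chain. A single pair also cannot show whether the same swap would read alike on a different core.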